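The compounds below may be only part of what the source reports. "The series", "measured", "known", "first", "only" and "open" are said of these compounds alone.

In a functional assay on MCF7 cells (Homo sapiens) for cytotoxicity, read by WST assay, with a stated time of 72 h (a lower number here means a stronger inhibitor, a higher number a weaker inhibitor), compound 1 `O=C1Nc2c(ccc(F)c2F)C1(c1ccccc1)c1ccc(O)cc1` gives 7.1 nM and compound 2 `O=C1Nc2c(ccc(F)c2F)C1(c1ccc(O)cc1)c1ccc(F)c(F)c1` gives 7.8 nM, a 1.1-fold higher number from compound 1 to compound 2 (0.04 log units; within the scatter). Compound 3 `O=C1Nc2c(ccc(F)c2F)C1(c1ccncc1)c1ccc(O)cc1` gives 37 nM, the highest of the three numbers. Compound 4 `CCCC1(c2ccc(O)cc2)C(=O)Nc2c1ccc(F)c2F` carries propyl in place of pyridin-4-yl on a saturated ring carbon. Among the compounds with values here, no measured compound has a chain at this carbon, so the evidence is indirect. Within the data shown here, removing pyridin-4-yl is the only kind of exchange seen to shift the number, as a 5.2-fold higher number from compound 1 to compound 3 (0.72 log units; beyond the scatter) and a 4.7-fold higher number from compound 2 to compound 3 (0.68 log units; beyond the scatter) show in reverse. A small shift toward a lower number is therefore expected, not clearly beyond the scatter. The expected step is a 1.9-fold lower number from compound 3 to compound 4 (0.27 log units; within the scatter). For compound 4 the estimated value is 20 nM, with an expected range from 5 nM to 90 nM.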

Compound 4, half-maximal inhibitory concentration: > 1000 nM
Compound 4 was reported as a limit; the forecaster's own chance of this, stated with the estimate: 3%; at least 50-fold (1.69 log units) between middle value and limit.
By their numbers in this assay, from the lowest: compounds 1 and 2 (each within the scatter of the next); then compound 3. At a limit, above all of these: compound 4.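

In this assay compound 4 is reported as a limit and not as a number: the limit of > 1000 nM in this assay, at which 1 of the 4 values shown sits.

At this saturated ring carbon, exchanges among phenyl, 3,4-difluorophenyl and pyridin-4-yl moved the number little or modestly, but a chain with no ring brings a much larger change: an at least 27-fold higher number from compound 3 to compound 4 (1.43 log units; beyond the scatter), an at least 120-fold higher number from compound 2 to compound 4 (2.10 log units; beyond the scatter) and an at least 140-fold higher number from compound 1 to compound 4 (2.14 log units; beyond the scatter). Among the compounds shown, then, only the loss of the aromatic ring takes the number to the limit.

From the compounds shown here alone, it remains open whether an ethyl or pentyl chain would behave like propyl. A cyclopropyl or benzyl group at this carbon could show whether any ring there restores the lower numbers.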